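The compounds below may be only part of what the source reports. "The series", "measured", "known", "first", "only" and "open" are said of these compounds alone.

Compound 1 `CC(C)=CCC/C(C)=C/CC/C(C)=C/CSc1ccccc1C(=O)N(C)C`: 38.6%
Compound 2 `CC(C)=CCC/C(C)=C/CC/C(C)=C/CSc1ccccc1C(N)=O`: 37.4%

Of the compounds shown here, two have been measured in a functional assay on PANC-1 cells (Homo sapiens) for inhibition, read by Western blot, with a stated time of 24 h, tested at 50 uM; a higher number here means more inhibition at the concentration tested (going by the name of the read-out), a lower number less inhibition. Compound 1 gives 38.6%, and compound 2 gives 37.4%, so the two numbers lie within the scatter of each other; compound 1 stands with the larger of the two figures, but the gap to compound 2, a number 1.2 percentage points lower from compound 1 to compound 2 (within the scatter), is not a real difference. Compound 3 `COCOC(=O)c1ccccc1SC/C=C(\C)CC/C=C(\C)CCC=C(C)C` has not been measured. It differs from compound 1 at one place: methoxymethoxy in place of dimethylamino on a carbonyl carbon. Among the measured compounds shown here, the only measured step, from compound 1 to compound 2, also changes the group on the carbonyl carbon and left this assay unchanged. For the measured compounds named here, that step is the one point of comparison, and the new group differs from both those seen so far. On this basis compound 3 is expected to give 37%, between 20% and 52%, a step of a number 1.6 percentage points lower from compound 1 to compound 3 (within the scatter), which is expected to stay within the scatter.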

Compound 3, a percentage reported as inhibition, at one concentration (the size of the read-out at that concentration, not a potency): 2.6%
The estimate for compound 3 lay 34.4 percentage points above the measured number; measured number outside the range, below it.
By their numbers in this assay, from the lowest: compound 3; then compounds 2 and 1 (each within the scatter of the next).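

In this assay, the group on the carbonyl carbon proves able to change the read-out: methoxymethoxy in place of dimethylamino gives a number 36 percentage points lower from compound 1 to compound 3 (beyond the scatter), and methoxymethoxy in place of amino gives a number 34.8 percentage points lower from compound 2 to compound 3 (beyond the scatter). The earlier pair had shown only that amino and dimethylamino can be exchanged here without a change beyond the scatter, whereas replacing either of them with methoxymethoxy does not preserve the read-out. No available evidence bears on the reason for this drop.

The compounds shown leave open whether the loss extends to other oxygen-linked groups at this place, such as methoxy or the hydroxyl of a carboxylic acid, or is particular to methoxymethoxy. They also leave open whether a cyclic amine such as piperidine on the carbonyl carbon would match compound 1 and compound 2.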